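Chain-end rearrangement on the shared core: compound 3

The compounds below may be only part of what the source reports. "The series", "measured", "known", "first", "only" and "open" are said of these compounds alone.

compound 1 `N#CNC(=N)NCCCCCn1nc(-c2ccccc2)ccc1=O`: 31%
compound 2 `CC/N=C(\S)NCCCCCCn1nc(-c2ccccc2)ccc1=O`: -5.6%

In a functional assay on the whole organism with Rattus norvegicus as the target, at a dose of 100 mg/kg (a lower number here means less inhibition, a higher number more inhibition at the dose given (going by the name of the read-out)), compound 1 gives 31%, the highest of the two numbers; compound 2 gives -5.6%. Among the measured compounds shown here, the single measured step is a number 36.6 percentage points lower from compound 1 to compound 2 (beyond the scatter). Compound 3 `CC/N=C(/NC#N)NCCCn1nc(-c2ccccc2)ccc1=O` differs from compound 1 by a group of 8 heavy atoms (4 carbon, 4 nitrogen; no ring) in place of a group of 8 heavy atoms (4 carbon, 4 nitrogen; no ring), on a saturated chain carbon, three bonds along the chain from an aromatic nitrogen. For the measured compounds named here, only that one step, which altered the same chain end of compound 1, bears on this change, and it was large and downward; a smaller fall is therefore expected for compound 3, not a rise. Compound 3 is estimated at 15%, between -10% and 40%, an expected step of a number 16 percentage points lower from compound 1 to compound 3 (beyond the scatter).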

Compound 3, a percentage reported as inhibition, in the whole organism at one dose (the size of the read-out at that dose, not a potency): 62.9%
Compound 3: the middle estimate sits 47.9 percentage points below what was measured; the measured number lies above the stated range.
By their numbers in this assay, from the lowest: compound 2; then compound 1; then compound 3.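

In this assay the rearranged chain end gives a number 31.9 percentage points higher from compound 1 to compound 3 (beyond the scatter) and thus a rise, whereas a number 36.6 percentage points lower from compound 1 to compound 2 (beyond the scatter) had shown only a fall for a change at the chain end. The leaving and entering groups hold the same heavy atoms, so that composition alone does not fix the read-out. No available measurement accounts for the rise.

Compound 3 alters the chain end and its attachment together, leaving their separate shares unresolved. From the compounds shown here alone, a longer chain bearing the same end group, or an amine at that chain end, remains open.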